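A few compounds are considered here, and "the series" means these few. Any claim that something is new, unique, unknown or untested is made for them only; others in the source may bear on it.

Values in a functional assay on OVCAR-4 cells (Homo sapiens) for inhibition; a lower number here means a stronger inhibitor of growth, a higher number a weaker inhibitor of growth:
Compound 1 `Nc1ccc(-c2nc3cc(F)ccc3s2)cc1`: 13500 nM
Compound 2 `Nc1ccc(-c2nc3cc(F)ccc3s2)cc1I`: < 10 nM

Compound 2 sits at the limit of < 10 nM in this assay, at which 1 of the 2 values shown sits; this is a limit and not a number. Compound 3 `Nc1ccc(-c2nc3cc(F)ccc3s2)cc1Br` carries bromo in place of iodo on an aromatic carbon, ortho to an amino group (bromo in place of iodo on an aromatic carbon). Going by the values given here, the one measured step bearing on this is an at least 1300-fold lower number from compound 1 to compound 2 (3.13 log units; beyond the scatter), a large step for iodo in place of hydrogen on the same carbon. Among the compounds with values here, no bromo compound has been measured, but compound 3 keeps a substituent there, so most of that gain is expected to hold. The expected change is small, at most slightly toward a higher number: a number no lower from compound 2 to compound 3 (the limit leaves the size open). Compound 3 is estimated at 10 nM, with an expected range of 2 nM to 100 nM.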

Compound 3, concentration for 50% growth inhibition: 24000 nM
For compound 3 the middle estimate is 2400-fold (3.38 log units) below the measured one; the measured number lies above the stated range.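

In this assay, swapping iodo for bromo on this carbon gives an at least 2400-fold higher number from compound 2 to compound 3 (3.38 log units; beyond the scatter), whereas replacing hydrogen with bromo gives only a 1.8-fold higher number from compound 1 to compound 3 (0.25 log units; within the scatter). Among these three compounds, the gain at this carbon therefore goes with iodo alone, not with just any halogen there. The value of compound 2 is a limit and not a number: the limit of < 10 nM in this assay, at which 1 of the 3 values shown sits.

From the compounds shown here alone, whether chloro, methyl or methoxy on this carbon would track iodo or bromo remains open. So does what separates iodo from bromo in this series.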